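The compounds below may be only part of what the source reports. "The series", "measured", "known", "first", "only" and "open" are said of these compounds alone.

Measured in a functional assay on HCT-116 cells (Homo sapiens) for antiproliferative activity, read by MTT assay, with a stated time of 72 h; on this read-out higher numbers stand for weaker inhibition and lower numbers for stronger inhibition:
- Compound 1 `O=C1COc2ccc(-c3cnc(Cl)c(NS(=O)(=O)c4ccc(F)cc4)c3)cc2N1C1CCCCC1`: > 40000 nM, a limit
- Compound 2 `COc1ncc(-c2ccc3c(c2)N(C2CCCCC2)C(=O)CO3)cc1NS(=O)(=O)c1ccc(F)cc1`: > 40000 nM, a limit

Neither compound has a true number yet. In this assay compound 1 stands only at the limit of > 40000 nM, so it offers a bound rather than a starting value.

Compound 3 `CC(C)N1C(=O)COc2ccc(-c3cnc(Cl)c(NS(=O)(=O)c4ccc(F)cc4)c3)cc21` keeps the core of compound 1 and alters one group: isopropyl in place of cyclohexyl on an amide-type nitrogen in a ring. In words, this is isopropyl in place of cyclohexyl on an amide-type nitrogen in a ring.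

Among the compounds with values here, only one measured step bears on this, and only loosely. It is a step that the two limits leave unreadable from compound 1 to compound 2, a change of methoxy in place of chloro on an aromatic carbon, which leaves the cyclohexyl untouched. That step has no readable size to carry over, and both compounds rest at the limit of > 40000 nM in this assay, at which 2 of the 2 values shown sit. Nothing measured therefore points to a gain or a loss in this assay, and no step beyond the scatter is expected in either direction.

The expected outcome is a number no higher from compound 1 to compound 3 (the limit leaves the size open), an estimate that may well end at the same limit. For compound 3 the estimated value is 40000 nM, with an expected range from 15000 nM to 80000 nM.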

Compound 3, half-maximal inhibitory concentration: 18900 nM
The estimate for compound 3 lay 2.1-fold (0.33 log units) above the measured number, within the range that was stated.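

In this assay, the group on the amide-type nitrogen is the first place shown where a change brings the read-out off the limit: isopropyl in place of cyclohexyl gives an at least 2.1-fold lower number from compound 1 to compound 3 (0.32 log units; beyond the scatter). This shows that the group at this position bears on the antiproliferative read-out with the rest of the core of compound 1 held constant, and the size of the step is only a lower bound, as compound 1 has a limit rather than a number. Compound 3 also gives the series its first true value, a reference against which later changes can be read in size, whereas the other values shown are limits: the limit of > 40000 nM in this assay, at which 2 of the 3 values shown sit.

The single step swaps a six-membered carbon ring for an open group and also lowers the heavy-atom count, so the compounds shown cannot separate the loss of the ring from the smaller size. As far as these compounds go, it also remains open how a methyl, an ethyl or a longer chain ending in an amine would read at this nitrogen, and whether methoxy in place of chloro on an aromatic carbon would shift the number once isopropyl is in place.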